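Replacing the 3-bromophenyl of compound 3: working notes

The source may report more compounds than this note shows. Statements on the series, on what has been measured and on what is new or still open speak of the compounds shown alone.

Within the data shown here, in an ADME assay on MDBK cells (Bos taurus) for cytotoxicity, read by MTT assay, with a stated time of 96 h (a lower number here means that less compound is tolerated, a higher number that more compound is tolerated), compound 3 `FC(F)(F)c1cccc(NC(=S)Nc2cccc(Br)c2)c1` gives 10000 nM and holds the lowest of the three numbers so far. Compound 1 `FC(F)(F)c1cccc(NC(=S)Nc2ccccc2)c1` gives 49000 nM and compound 2 `Fc1ccc(NC(=S)Nc2cccc(C(F)(F)F)c2)cc1` gives 41000 nM in the same read-out. Compound 4 `C=C(C)CNC(=S)Nc1cccc(C(F)(F)F)c1` is still unmeasured and carries 2-methylprop-2-en-1-yl in place of 3-bromophenyl on an amide-type nitrogen.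

Among the measured compounds shown here, three measured steps bear on the group that leaves. Bromo in place of hydrogen gives a 4.9-fold lower number from compound 1 to compound 3 (0.69 log units; beyond the scatter) and the exchange of 4-fluorophenyl for 3-bromophenyl gives a 4.1-fold lower number from compound 2 to compound 3 (0.61 log units; beyond the scatter) as a step of similar size. Fluoro in place of hydrogen gives only a 1.2-fold lower number from compound 1 to compound 2 (0.08 log units; within the scatter) and shows no separation between those two compounds. Compound 3 thus stands apart from the other two, and the 3-bromophenyl is what compound 4 gives up. For the measured compounds named here, no measured step replaces an aromatic ring with an open chain, so the size of the change remains an extrapolation. A higher number in this assay is expected, returning towards the level of compound 1 and compound 2. The expected step is a 3.5-fold higher number from compound 3 to compound 4 (0.54 log units; beyond the scatter) and its size is uncertain. Compound 4 is estimated at 35000 nM with an expected range from 12000 nM to 100000 nM in this read-out.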

Compound 4, half-maximal cytotoxic concentration: > 100000 nM
Compound 4 gave a limit, no number; the forecaster's own chance of this, stated with the estimate: 20%; middle value at least 2.8-fold (0.45 log units) from the limit.
By their numbers in this assay, from the lowest: compound 3; then compounds 2 and 1 (each within the scatter of the next). At a limit, above all of these: compound 4.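

Three aryl compounds alone could not show whether this amide-type nitrogen needs an aromatic ring for the read-out to stay high; compound 4 now shows an open chain there. In this assay, compound 4 stands at a limit of the assay and not at a number: the limit of > 100000 nM in this assay, at which 1 of the 4 values shown sits. Even so, 2-methylprop-2-en-1-yl on this nitrogen gives an at least 10-fold higher number from compound 3 to compound 4 (1.00 log units; beyond the scatter) and an at least 2.4-fold higher number from compound 2 to compound 4 (0.38 log units; beyond the scatter), while the comparison with the unsubstituted phenyl gives an at least 2.0-fold higher number from compound 1 to compound 4 (0.30 log units; that floor lies within the scatter), so that the ring-to-chain exchange clearly clears the scatter against the two halogenated aryl groups, but its floor does not against phenyl.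

Whether the higher number follows from losing the aromatic ring or from the 2-methylprop-2-en-1-yl group itself stays open; the compounds shown hold only this one open chain, and the true size of all three steps remains unknown. A saturated propyl chain, or a chain ending in an amine or a carboxylic acid, on the same amide-type nitrogen would show whether the result extends beyond this single group.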